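Octylsulfonamido benzoic acids: moving the aryl hydroxyl

This account rests on a few compounds, and the source may have more. Where it says the series, first, only, none or still open, it means among the compounds named here.

Measured so far in an assay on mitochondria (strain BALB/c) for inhibition of glycerol-3-phosphate acyltransferase 1, mitochondrial (Mus musculus), read by scintillation counting, with a stated time of 10 min; a higher number here means a weaker inhibitor, a lower number a stronger inhibitor:
- compound 1, `CCCCCCCCS(=O)(=O)Nc1cc(-c2ccc(Cl)cc2)ccc1C(=O)O`: 18100 nM
- compound 2, `CCCCCCCCS(=O)(=O)Nc1cc(-c2cccc(F)c2)ccc1C(=O)O`: 32600 nM
- compound 3, `CCCCCCCCS(=O)(=O)Nc1cc(-c2ccccc2O)ccc1C(=O)O`: 63100 nM

Compound 3 carries the highest of the three numbers in this assay. Against compound 2 the step of a 1.9-fold higher number from compound 2 to compound 3 (0.29 log units; within the scatter) stays within the scatter; against compound 1 the step of a 3.5-fold higher number from compound 1 to compound 3 (0.54 log units; beyond the scatter) goes beyond it, though only modestly. The step of a 1.8-fold higher number from compound 1 to compound 2 (0.26 log units; within the scatter) between the two halogenated analogues is also within the scatter.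

Compound 4, `CCCCCCCCS(=O)(=O)Nc1cc(-c2ccc(O)cc2)ccc1C(=O)O`, is not yet measured. It differs from compound 3 only in the pendant ring: 4-hydroxyphenyl in place of 2-hydroxyphenyl on an aromatic carbon. The same atoms are present, joined differently.

Among the measured compounds shown here, no measured step bears directly on the position of a hydroxyl on this ring. The three steps so far exchange one substituted phenyl for another and all fall within or just beyond the scatter, so the series has shown little sensitivity to this ring. The expectation for compound 4 is therefore a small step of a 1.6-fold lower number from compound 3 to compound 4 (0.20 log units; within the scatter), most likely not beyond the scatter, with the direction uncertain. Compound 4 is estimated at 40000 nM, with a range of 15000 nM to 100000 nM.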

Compound 4, half-maximal inhibitory concentration: 64800 nM
Compound 4: middle estimate off by 1.6-fold (0.21 log units), on the low side, within the range that was stated.
By their numbers in this assay, from the lowest: compounds 1, 2, 3 and 4 (each within the scatter of the next, the first and the last beyond it).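

In this assay, among the compounds shown here, the pair of hydroxyphenyl isomers is the first to keep the ring substituent the same and change only its place, and the step is a 1.0-fold higher number from compound 3 to compound 4 (0.01 log units; within the scatter), so 2-hydroxyphenyl and 4-hydroxyphenyl cannot be told apart at this position. Set against the halogenated analogues, the 4-hydroxyphenyl group gives a 2.0-fold higher number from compound 2 to compound 4 (0.30 log units; within the scatter) and a 3.6-fold higher number from compound 1 to compound 4 (0.55 log units; beyond the scatter), the same picture as the 2-hydroxyphenyl group; the second of these steps is a direct exchange of chloro for hydroxy at one ring carbon and is the only one of the two beyond the scatter, and only modestly so. Nothing available explains the lack of a separation between the two hydroxyl placements or the modest gap between chloro and hydroxy.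

Still open, on these data alone, is whether any group on this ring moves the series clearly, for example a methoxy group, an amine or a carboxylic acid in place of the hydroxyl. Also open, as far as these compounds go, is whether the same flatness holds with a shorter chain in place of the octyl chain.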